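The compounds below may be only part of what the source reports. "The series", "measured", "known", "first", "only" and "open" are said of these compounds alone.

Within the data shown here, compound 1 `Cc1ccc(C(=O)Nc2sc3c(c2C(N)=O)CCN(Cc2c(Cl)cccc2Cl)C3)cc1` is one of two compounds measured in a functional assay on MKN-74 cells (Homo sapiens) for antiproliferative activity, with a stated time of 24 h (a higher number here means a weaker inhibitor, a lower number a stronger inhibitor), and in that assay compound 1 gives 12300 nM. Among the measured compounds shown here, its only measured neighbour is compound 2 `Cc1ccc(C(=O)Nc2sc3c(c2C(N)=O)CCN(Cc2ccc(Cl)cc2Cl)C3)cc1`, which in this assay gives 25500 nM; the step is a 2.1-fold higher number from compound 1 to compound 2 (0.32 log units; beyond the scatter), so compound 1 stands with the lower of the two numbers. Compound 3 `NC(=O)c1c(NC(=O)c2cccc([N+](=O)[O-])c2)sc2c1CCN(Cc1c(Cl)cccc1Cl)C2` differs from compound 1 in another place altogether: 3-nitrophenyl in place of 4-methylphenyl on a carbonyl carbon. For the measured compounds named here, no measured step touches the aryl group on the carbonyl carbon; the one step on record concerns the group on the ring amine nitrogen, and it was only of modest size. There is therefore no basis for expecting more than a modest shift for compound 3, in either direction. Compound 3 is accordingly estimated at 15000 nM in this assay, within a range of 5000 nM to 45000 nM, which corresponds to an expected step of a 1.2-fold higher number from compound 1 to compound 3 (0.09 log units; within the scatter).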

Compound 3, half-maximal inhibitory concentration: 13500 nM
Estimate against measurement, compound 3: 1.1-fold (0.05 log units) above; the measured number falls inside the stated range.
By their numbers in this assay, from the lowest: compounds 1, 3 and 2 (each within the scatter of the next, the first and the last beyond it).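

Among these compounds, the first step at the aryl group on the carbonyl carbon, 3-nitrophenyl in place of 4-methylphenyl, gives in this assay a 1.1-fold higher number from compound 1 to compound 3 (0.04 log units; within the scatter), so this position takes the exchange without a change beyond the scatter. Among the compounds shown here, the entering group carries hydrogen-bond acceptors that the leaving group lacks, yet this one pair shows no separation between the two, and the only step so far beyond the scatter remains the one at the ring amine nitrogen, a 2.1-fold higher number from compound 1 to compound 2 (0.32 log units; beyond the scatter). No measurement available here accounts for this outcome.

Going by these compounds, it remains open whether the same holds when the aryl group gives way to an amine, a carboxylic acid or a longer chain on the carbonyl carbon. On these data alone, it is also open whether 3-nitrophenyl would read the same alongside the 2,4-dichlorophenyl group of compound 2.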